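Dimethylamino to Diethylamino on a Bcl-2 Binder

This account rests on a few compounds, and the source may have more. Where it says the series, first, only, none or still open, it means among the compounds named here.

Compound 1 `CC1(C)CCC(CN2CCN(c3ccc(C(=O)NS(=O)(=O)c4ccc(NCC5CCOCC5)c([N+](=O)[O-])c4)c(Oc4cnc5[nH]ccc5c4)c3)CC2)=C(c2ccc(C(F)(F)F)cc2)C1`: 1.5 nM in an assay on isolated protein for displacement of a labelled ligand from Apoptosis regulator Bcl-2 (Homo sapiens), with a stated time of 15 min; on this read-out higher numbers stand for weaker inhibition and lower numbers for stronger inhibition
Compound 2 `CN(C)CCCNc1ccc(S(=O)(=O)NC(=O)c2ccc(N3CCN(CC4=C(c5ccc(C(F)(F)F)cc5)CC(C)(C)CC4)CC3)cc2Oc2cnc3[nH]ccc3c2)cc1[N+](=O)[O-]`: 0.89 nM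

Compound 2 gives the lowest of the two numbers, but compound 1 sits within the scatter of it, so neither can be called the stronger binder. Compound 3 `CCN(CC)CCCNc1ccc(S(=O)(=O)NC(=O)c2ccc(N3CCN(CC4=C(c5ccc(C(F)(F)F)cc5)CC(C)(C)CC4)CC3)cc2Oc2cnc3[nH]ccc3c2)cc1[N+](=O)[O-]` is compound 2 with diethylamino in place of dimethylamino on a saturated chain carbon, three bonds along the chain from a nitrogen on an aromatic ring. For the measured compounds named here, the only measured step, a 1.7-fold lower number from compound 1 to compound 2 (0.23 log units; within the scatter), changed a different part of the chain and stayed within the scatter, so nothing here points to a large effect. The expected step is a 1.0-fold higher number from compound 2 to compound 3 (0.00 log units; within the scatter), with no change beyond the scatter. Compound 3 is therefore estimated at 0.9 nM, ranging from 0.4 nM to 2 nM.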

Compound 3, half-maximal inhibitory concentration: 0.3 nM
Estimate against measurement, compound 3: 3.0-fold (0.48 log units) above; measured number outside the range, below it.
By their numbers in this assay, from the lowest: compound 3; then compounds 2 and 1 (each within the scatter of the next).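

Changing the end of this chain can move the number beyond the scatter: swapping dimethylamino for diethylamino gives a 3.0-fold lower number from compound 2 to compound 3 (0.47 log units; beyond the scatter), whereas the earlier step stayed within it. Set against the oxan-4-yl end, 2-(diethylamino)ethyl gives a 5.0-fold lower number from compound 1 to compound 3 (0.70 log units; beyond the scatter). Nothing shown explains why diethylamino gives the lower number.

Still open, on these data alone, is whether the number keeps falling with a larger group on this nitrogen, such as dipropylamino. As far as these compounds go, a piperidine ring at the chain end, or a shorter chain carrying diethylamino, also remains untested here.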